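This account rests on a few compounds, and the source may have more. Where it says the series, first, only, none or still open, it means among the compounds named here.

Measured compounds:
Compound 1 `C=CC1=C(C(=O)NCc2ccc(Cl)cc2)C(c2ccc(F)cc2)OC1`
Compound 2 `C=CC1=C(C(=O)NC(C)(C)C)C(c2ccc(F)cc2)OC1`

In a functional assay on HeLa cells (Homo sapiens) for cytotoxicity, read by MTT assay, with a stated time of 24 h (a lower number here means a stronger inhibitor, a higher number a weaker inhibitor), compound 1 reaches only the limit of the assay, > 100000 nM, and gives no number. In this assay compound 2 likewise reaches only the limit, > 100000 nM. The step that the two limits leave unreadable from compound 1 to compound 2 therefore cannot be read, because of the limit of > 100000 nM in this assay, at which 2 of the 2 values shown sit. Compound 2 thus stands at a limit only, with no number to place it against anything else.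

Compound 3 `C=CC1=C(C(=O)Nc2cccc(C)c2)C(c2ccc(F)cc2)OC1` is not yet measured. It differs from compound 2 in one place: 3-methylphenyl in place of tert-butyl on an amide-type nitrogen. Going by the values given here, the one measured step, a step that the two limits leave unreadable from compound 1 to compound 2, also changed the group on the amide-type nitrogen and gave no readable size, so nothing here says how far such a change moves the read-out. The expectation for compound 3 is therefore only that it stays at the limit, an expected step of a number no higher from compound 2 to compound 3 (the limit leaves the size open), with wide uncertainty. For compound 3 the estimate is 100000 nM with a range from 30000 nM to 300000 nM.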

Compound 3, half-maximal inhibitory concentration: "not active" (no number reported)
The entry for compound 3 holds no number; there is nothing to compare the estimate with.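

Going by these compounds alone, compound 3 is reported in this assay only as not active, with no number, so no step from compound 2 to compound 3 can be read. The compounds shown leave open whether changing the group on the amide-type nitrogen moves the read-out at all.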